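Side-chain methylation in the series: compound 4

This account rests on a few compounds, and the source may have more. Where it says the series, first, only, none or still open, it means among the compounds named here.

Measured so far in a functional assay on A549 cells (Homo sapiens) for inhibition, read by XTT assay, with a stated time of 48 h; a higher number here means a weaker inhibitor, a lower number a stronger inhibitor:
- compound 1 `COc1ccc(C(=O)/C(=C/c2ccc(Cl)cc2Cl)CCOC(C)=O)cc1` gives 69200 nM
- compound 2 `COc1ccc(C(=O)/C(=C/c2ccc([N+](=O)[O-])cc2)CCOC(C)=O)cc1` gives > 100000 nM, a limit of the assay
- compound 3 `COc1ccc(C(=O)/C(=C/c2ccc(Cl)cc2)CCOC(C)=O)cc1` gives 86000 nM

Compound 1 holds the lowest of the two numbers; the nearest is a 1.2-fold higher number from compound 1 to compound 3 (0.09 log units; within the scatter). The remaining value is a limit (the limit of > 100000 nM in this assay, at which 1 of the 3 values shown sits), so nothing more can be said about it.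

Compound 4 `COc1ccc(C(=O)/C(=C/c2ccc(Cl)cc2Cl)CC(C)OC(C)=O)cc1` differs from compound 1 by methyl in place of hydrogen on a saturated chain carbon bound to an oxygen next to a carbonyl group and a saturated chain carbon. Every measured step changes the aryl group on the chain: an at least 1.4-fold higher number from compound 1 to compound 2 (0.15 log units; that floor lies within the scatter) and an at least 1.1-fold lower number from compound 2 to compound 3 (0.06 log units; that floor lies within the scatter); none touches the acetoxy chain, so none bears directly on this change. Without a relevant precedent, no shift beyond the scatter is expected in this assay; the expected step is a 1.0-fold higher number from compound 1 to compound 4 (0.00 log units; within the scatter). Compound 4 is therefore estimated at 70000 nM, expected between 30000 nM and 160000 nM.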

Compound 4, half-maximal inhibitory concentration: 40300 nM
Estimate against measurement, compound 4: 1.7-fold (0.24 log units) above; measured number inside the range.
By their numbers in this assay, from the lowest: compounds 4, 1 and 3 (each within the scatter of the next, the first and the last beyond it). At a limit, above all of these: compound 2.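

In this assay, methyl in place of hydrogen on a saturated chain carbon bound to an oxygen next to a carbonyl group and a saturated chain carbon gives a 1.7-fold lower number from compound 1 to compound 4 (0.23 log units; within the scatter). Among these compounds, this is the first step read on the acetoxy chain rather than on the aryl group, and at this position the added methyl moves the number by no more than the scatter. Nothing at hand bears on the cause of this step.

Going by these compounds, whether an ethyl group or a longer chain at this carbon, or an amine or a free hydroxyl in place of the acetoxy group, would give a step beyond the scatter stays open. So does whether the methyl step holds with the 4-chlorophenyl group of compound 3.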